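Removing a Bromine from a Bis-indole Cytotoxic Compound

A few compounds are considered here, and "the series" means these few. Any claim that something is new, unique, unknown or untested is made for them only; others in the source may bear on it.

Measured so far:
compound 1, `O=C1N[C@@H](c2c[nH]c3ccccc23)CN=C1c1c[nH]c2ccccc12`: 5 ug/mL
compound 2, `O=C1NC[C@@H](c2c[nH]c3cc(Br)ccc23)N=C1c1c[nH]c2ccccc12`: 7.6 ug/mL

Both compounds were tested in an ADME assay on SK-MEL-2 cells (Homo sapiens) for cytotoxicity; a higher number here means that more compound is needed for the effect, a lower number that less compound is needed. Compound 1 gives 5 ug/mL and compound 2 gives 7.6 ug/mL, so compound 2 has the higher of the two numbers, though the gap to compound 1 lies within the usual scatter of this assay, and the two cannot be told apart on these numbers alone.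

Compound 3, `O=C1NC[C@@H](c2c[nH]c3ccccc23)N=C1c1c[nH]c2ccccc12`, has not yet been measured. It differs from compound 2 in one place: hydrogen in place of bromo on an aromatic carbon. Going by the values given here, no pair of measured compounds shows what such a change does here, so there is no direct guide from the data.

The step expected in this assay from compound 2 to compound 3 is a 1.2-fold higher number from compound 2 to compound 3 (0.07 log units; within the scatter), which is no more than the scatter. On that basis compound 3 is estimated at 9 ug/mL, with a range from 4 ug/mL to 20 ug/mL.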

Compound 3, concentration for half-maximal effect: 13.7 ug/mL
Beside the measured number, compound 3's estimate is 1.5-fold (0.18 log units) below it; the measured number falls inside the stated range.
By their numbers in this assay, from the lowest: compounds 1, 2 and 3 (each within the scatter of the next, the first and the last beyond it).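

Going by these compounds alone, this pair gives the first direct reading of what the bromo on this aromatic carbon contributes: in this assay, hydrogen in place of bromo gives a 1.8-fold higher number from compound 2 to compound 3 (0.26 log units; within the scatter). Within this single pair, then, the compound keeps a measurable effect on these cells without the bromine atom, and the step stays inside what repeat measurements alone could produce. Nothing available here bears on why the two compounds compare as they do.

A single pair cannot show whether a step of this size is real or only scatter, and it speaks for this one carbon of this one ring. Going by these compounds, how a chlorine atom, a methoxy group or an amine on the same aromatic carbon would read in this assay remains open, so any trend across substituents at this place is still unknown.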